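Aryl exchange and a phenoxy replacement in the series

A few compounds are considered here, and "the series" means these few. Any claim that something is new, unique, unknown or untested is made for them only; others in the source may bear on it.

Measured so far in a functional assay on A549 cells (Homo sapiens) for cytotoxicity, read by MTT assay, with a stated time of 48 h; on this read-out lower numbers stand for stronger inhibition and higher numbers for weaker inhibition:
- compound 1 `Cc1cccc(/C=C/[C@](C)(O)CC[C@@H]2[C@@]3(C)CCCC(C)(C)[C@@H]3CC[C@@]2(C)O)c1C` gives 3800 nM
- compound 2 `CC1(C)CCC[C@]2(C)[C@@H](CC[C@@](C)(O)/C=C/c3ccc(Cl)nc3)[C@](C)(O)CC[C@@H]12` gives 3280 nM
- compound 3 `CC1(C)CCC[C@]2(C)[C@@H](CC[C@@](C)(O)/C=C/c3ccc(Br)cc3)[C@](C)(O)CC[C@@H]12` gives 43200 nM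

Compound 3 has the highest number of the three. Compound 4 `CC1(C)CCC[C@]2(C)[C@@H](CC[C@@](C)(O)/C=C/c3ccc(Oc4ccccc4)cc3)[C@](C)(O)CC[C@@H]12` has phenoxy in place of bromo on an aromatic carbon, para to a large group, and the change counts as phenoxy in place of bromo on an aromatic carbon in full. For the measured compounds named here, no measured step alters this position alone. The closest evidence is exchange of the whole aromatic group. The step of an 11-fold higher number from compound 1 to compound 3 (1.06 log units; beyond the scatter) and the step of a 13-fold higher number from compound 2 to compound 3 (1.12 log units; beyond the scatter) are both large, while the step of a 1.2-fold lower number from compound 1 to compound 2 (0.06 log units; within the scatter) stays within the scatter. Compound 3 stands at 43200 nM at the top of this small range, so a moderate step to a lower number is expected in this assay, though a result near compound 3 remains possible. The expected change is a 3.1-fold lower number from compound 3 to compound 4 (0.49 log units; beyond the scatter) on this estimate. For compound 4 the estimated value is 14000 nM with an expected range of 4000 nM to 45000 nM in this read-out.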

Compound 4, half-maximal inhibitory concentration: 3200 nM
Compound 4: middle estimate off by 4.4-fold (0.64 log units), on the high side; measured number below the stated range.
By their numbers in this assay, from the lowest: compounds 4, 2 and 1 (each within the scatter of the next); then compound 3.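

For the compounds shown here, on the aromatic carbon para to a large group, the change of one substituent with everything else held constant gives a 14-fold lower number from compound 3 to compound 4 (1.13 log units; beyond the scatter) in this assay, whereas the earlier steps exchanged the whole aromatic group. With phenoxy in place of bromo, compound 4 lies within the scatter of compound 2, so the high number of compound 3 goes with bromo at this place and not with a phenyl group as such. The data at hand offer no explanation for this step.

Whether the oxygen link or the added ring accounts for the change stays open, and methoxy, benzyl or an anilino amine at this place would separate the two. From the compounds shown here alone, how a carboxylic acid at the same carbon would read in this assay is also open.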